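Series notes: from compound 2 to compound 3

A few compounds are considered here, and "the series" means these few. Any claim that something is new, unique, unknown or untested is made for them only; others in the source may bear on it.

Compound 2 `COC(=O)C(Cc1cccc(C(=N)N)c1)C(/C=C/c1ccccc1)NC(=O)c1ccc(-c2ccc(OC)cc2)cc1` and compound 1 `COC(=O)C(Cc1cccc(C(=N)N)c1)C(/C=C/c1ccccc1)NC(=O)c1ccc(-c2ccc(C)cc2)cc1` share one core and differ in a single substituent. In an assay on isolated protein (Oryctolagus cuniculus) for inhibition of Trypsin (Homo sapiens) (a higher number here means a weaker inhibitor, a lower number a stronger inhibitor), compound 1 gives 2800 nM and compound 2 gives 2900 nM; the step of a 1.0-fold higher number from compound 1 to compound 2 (0.02 log units; within the scatter) is within the scatter. Among the compounds with values here, compound 2 thus holds the highest of the two numbers so far, with compound 1 nearest and indistinguishable from it. Compound 3 `COC(=O)C(Cc1cccc(C(=N)N)c1)C(/C=C/c1ccccc1)NC(=O)c1ccc(-c2ccc(OC)cc2OC)cc1` carries one further change: methoxy in place of hydrogen on an aromatic carbon. Within the data shown here, no measured pair shows this kind of change; the only measured step, from compound 1 to compound 2, swaps one small group for another and was flat, so the series gives no basis for a shift in either direction. The expected step of no change at the digits printed from compound 2 to compound 3 (within the scatter) is therefore none beyond the scatter. Compound 3 is estimated at 2900 nM in this assay, with a range from 1200 nM to 7000 nM.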

Compound 3, half-maximal inhibitory concentration: 2900 nM
Beside the measured number, compound 3's estimate shows no gap at the digits printed; the measured number falls inside the stated range.
By their numbers in this assay, from the lowest: compounds 1, 2 and 3 (each within the scatter of the next).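

In this assay, within the data shown here, the methoxy in place of hydrogen, on the aromatic carbon ortho to a large group and meta to a methoxy group, gives no change at the digits printed from compound 2 to compound 3 (within the scatter) and so adds a first reading at this position: the added group leaves the number unmoved. The larger swap of 2,4-dimethoxyphenyl in place of 4-methylphenyl gives a 1.0-fold higher number from compound 1 to compound 3 (0.02 log units; within the scatter) and is equally flat, so the two changes on this aromatic ring seen so far both stay within the scatter. No supporting data bear on why this position is flat.

The compounds shown leave open whether this position stays flat with an amine, a carboxylic acid or a longer chain such as butoxy. They also leave open whether hydrogen in place of the 4-methoxy group of compound 3 would read the same.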